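Sulfanyl for phenoxy: from compound 3 to compound 4

The compounds below may be only part of what the source reports. "The series", "measured", "known", "first", "only" and "open" are said of these compounds alone.

Within the data shown here, in an ADME assay on MCF7 cells (Homo sapiens) for inhibition (a higher number here means a weaker inhibitor, a lower number a stronger inhibitor), the compounds measured so far give only limits and no numbers. Compound 3 (`O=C(c1ccccc1)c1cc2c(F)c(F)c(Oc3ccccc3Br)c(F)c2s1`) reads > 25000 nM, which is a limit. Compound 2 (`O=C(c1ccccc1)c1cc2c(F)c(F)c(-n3ccnc3)c(F)c2s1`) reads > 60000 nM, also a limit. Compound 3 therefore stands only at the limit of > 25000 nM in this assay, at which 2 of the 3 values shown sit.

Compound 4 (`O=C(c1ccccc1)c1cc2c(F)c(F)c(Sc3ccccc3Br)c(F)c2s1`) follows from compound 3 by one change: (2-bromophenyl)sulfanyl in place of 2-bromophenoxy on an aromatic carbon. Among the measured compounds shown here, the only measured step on this aromatic carbon is a step that the two limits leave unreadable from compound 2 to compound 3, so it sets no size for the change. Compound 1 (`COC(=O)c1cc2c(F)c(F)c(Sc3ccccc3Br)c(F)c2s1`) carries the same (2-bromophenyl)sulfanyl group but otherwise differs from compound 4. With that group, compound 1 reads > 25000 nM, again a limit.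

With no readable step to scale from, no change beyond the scatter is expected in this assay, in either direction. The expected step is a number no higher from compound 3 to compound 4 (the limit leaves the size open). For compound 4 the estimated value is 25000 nM, with an expected range of 7000 nM to 60000 nM, and a reading that is only a limit is quite likely.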

Compound 4, half-maximal inhibitory concentration: > 25000 nM
Compound 4 gave a limit, no number; the forecaster's own chance of this, stated with the estimate: 65%; the middle value sits exactly at the limit.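

In this assay compound 4 gives only a limit, as do compound 1, compound 2 and compound 3, so the steps to compound 4 from each of them cannot be read. The compounds shown leave open whether (2-bromophenyl)sulfanyl in place of 2-bromophenoxy, or any other change here, alters inhibition at all.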